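The source may report more compounds than this note shows. Statements on the series, on what has been measured and on what is new or still open speak of the compounds shown alone.

Compound 1 `COc1c(OCCCN2CCNCC2)cc(O)c2c(=O)cc(-c3ccccc3)oc12` gives 10100 nM in a functional assay on A549 cells (Homo sapiens) for cytotoxicity, read by MTT assay, with a stated time of 48 h; on this read-out higher numbers stand for weaker inhibition and lower numbers for stronger inhibition.
Compound 2 `COc1c(O)cc(O)c2c(=O)cc(-c3ccc(Cl)cc3)oc12` gives "not determined" (no result reported) in this assay.
Compound 3 `CC(CO)NCCOc1c(O)cc(O)c2c(=O)cc(-c3ccccc3)oc12` gives "not determined" (no result reported) in this assay.

For the measured compounds named here, compound 1 holds the only number on this read-out. Going by the values given here, compound 2 and compound 3 carry no result in this assay, so no step between measured compounds can be read from the series, and nothing is known of how the shared core answers to any change at the chain.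

Compound 4 `CCN(CC)CCCCOc1cc(O)c2c(=O)cc(-c3ccccc3)oc2c1OC` differs from compound 1 by (diethylamino)methyl in place of piperazin-1-yl on a saturated chain carbon, three bonds along the chain from an oxygen on an aromatic ring. The group that leaves and the group that enters are of equal atom count, each with one nitrogen kept, one donor lost. Among the compounds with values here, with no measured step to rest on, the step from compound 1 to compound 4 a 1.0-fold lower number from compound 1 to compound 4 (0.00 log units; within the scatter) is expected to stay within the scatter, in either direction. Compound 4 is estimated at 10000 nM, with a range of 4000 nM to 25000 nM.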

Compound 4, half-maximal inhibitory concentration: 1000 nM
Beside the measured number, compound 4's estimate is 10-fold (1.00 log units) above it; the measured number lies below the stated range.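

In this assay, the chain position responds to this change: 4-(diethylamino)butyl in place of 3-(piperazin-1-yl)propyl gives a 10-fold lower number from compound 1 to compound 4 (1.00 log units; beyond the scatter) and marks stronger inhibition, so the position is not indifferent to the group it carries. This single step changes the amine and the chain length together, and it cannot separate the two. Nothing available bears on the cause of the step.

Still open, on these data alone, is how a 3-(diethylamino)propyl chain or a 4-(piperazin-1-yl)butyl chain would compare on this read-out. As far as these compounds go, the response to a morpholine at the chain end also remains open.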